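The source may hold more compounds than are shown below. What is called first, only, known or untested is meant among the compounds shown, and "the series" means these compounds.

Going by the values given here, compound 1 `O=C1NC(=O)/C(=C/c2ccc(OCCSc3nnc(Cc4ccccc4)[nH]3)cc2)S1` gives the highest of the three numbers so far: in a functional assay on the whole organism (plasma, strain Wistar) with Rattus norvegicus as the target, with a stated time of 15 days, at a dose of 100 mg/kg by the oral route (on this read-out higher numbers stand for a stronger effect at the one dose given and lower numbers for a weaker effect), compound 1 gives 34.4%. Compound 3 `O=C1NC(=O)/C(=C/c2ccc(OCCSc3nnc(-c4ccc(Cl)cc4)[nH]3)cc2)S1` gives 28.9%, and compound 2 `O=C1NC(=O)/C(=C/c2ccc(OCCSc3nnc(-c4ccc([N+](=O)[O-])cc4)[nH]3)cc2)S1` gives 18%. Compound 4 `COc1ccc(-c2nnc(SCCOc3ccc(/C=C4\SC(=O)NC4=O)cc3)[nH]2)cc1` differs from compound 1 at one place: 4-methoxyphenyl in place of benzyl on an aromatic carbon. Among the compounds with values here, two measured steps bear on this, both replacing benzyl by a substituted phenyl on the same aromatic carbon: a number 5.5 percentage points lower from compound 1 to compound 3 (within the scatter) and a number 16.4 percentage points lower from compound 1 to compound 2 (beyond the scatter). One fell within the scatter, the other modestly beyond it, so a small decrease in this assay is expected for compound 4. Compound 4 is therefore estimated at 27%, with a range from 14% to 40%. This estimate means an expected step of a number 7.4 percentage points lower from compound 1 to compound 4 (within the scatter).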

Compound 4, a percentage reported as activity, at one dose (the size of the read-out at that dose, not a potency): 43.4%
Compound 4: middle estimate off by 16.4 percentage points, on the low side; the measured number lies above the stated range.
By their numbers in this assay, from the lowest: compound 2; then compounds 3, 1 and 4 (each within the scatter of the next, the first and the last beyond it).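

In this assay a substituted phenyl on the aromatic carbon between two ring nitrogen atoms need not fall short of benzyl, as 4-methoxyphenyl shows (a number 9 percentage points higher from compound 1 to compound 4 (within the scatter)). Among the phenyl compounds the substituent decides the outcome: methoxy stands apart from chloro (a number 14.5 percentage points higher from compound 3 to compound 4 (beyond the scatter)) and from nitro (a number 25.4 percentage points higher from compound 2 to compound 4 (beyond the scatter)). Going by these compounds, whether an amine or a hydroxyl group on the phenyl ring would match methoxy remains open. Nothing in the data accounts for these steps, so their cause also stays open.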